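From 1-benzofuran-5-yl to 1H-indol-5-yl in the series

This account rests on a few compounds, and the source may have more. Where it says the series, first, only, none or still open, it means among the compounds named here.

Measured so far:
- compound 1 `Cn1c(=O)c(S(=O)(=O)c2ccc(F)cc2)cc2cnc(Nc3ccc4occc4c3)nc21` gives 5000 nM
- compound 2 `Cn1c(=O)c(S(=O)(=O)c2ccc(F)cc2F)cc2cnc(Nc3ccc4sccc4c3)nc21` gives 500 nM

In a functional assay on K562 cells (Homo sapiens) for inhibition, read by trypan blue exclusion, with a stated time of 72 h (a higher number here means a weaker inhibitor, a lower number a stronger inhibitor), compound 1 stands at 5000 nM, the higher of the two numbers, while compound 2 gives 500 nM, a gap beyond the usual scatter. Compound 3 `Cn1c(=O)c(S(=O)(=O)c2ccc(F)cc2)cc2cnc(Nc3ccc4[nH]ccc4c3)nc21` keeps the core of compound 1 and carries 1H-indol-5-yl in place of 1-benzofuran-5-yl on a nitrogen on an aromatic ring. Among the measured compounds shown here, the measured compounds offer no step for this change. A moderate step towards a lower number in this assay is expected, although a step within the scatter remains possible. For the measured compounds named here, the only support is that compound 2, at 500 nM, shows lower numbers occur. The expected change is a 3.3-fold lower number from compound 1 to compound 3 (0.52 log units; beyond the scatter). The estimate for compound 3 is 1500 nM, with an expected range of 300 nM to 6000 nM.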

Compound 3, half-maximal inhibitory concentration: 200 nM
Beside the measured number, compound 3's estimate is 7.5-fold (0.88 log units) above it; the whole stated range lies above it.
By their numbers in this assay, from the lowest: compound 3; then compound 2; then compound 1.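

In this assay, 1H-indol-5-yl in place of 1-benzofuran-5-yl on a nitrogen on an aromatic ring gives a 25-fold lower number from compound 1 to compound 3 (1.40 log units; beyond the scatter), a large step beyond the scatter. This position therefore responds strongly to an exchange of one ring hetero atom, oxygen for nitrogen, with the heavy-atom count unchanged and the rest of the core of compound 1 kept. The entering group brings a hydrogen-bond donor and loses a hydrogen-bond acceptor, but no measurement at hand explains the step.

Going by these compounds, what a 1-methyl-1H-indol-5-yl group, with a methyl on the ring nitrogen in place of its hydrogen, would do at this position remains open. Compound 2 differs from compound 1 and compound 3 in more than one place, so whether its second fluorine adds to this change cannot be read.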